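Cyano for Fluoro on the Benzyl Ring: Permeability Outlook

This account rests on a few compounds, and the source may have more. Where it says the series, first, only, none or still open, it means among the compounds named here.

Compound 1 `CCC(CC)c1ccc2c(NCCCNCc3cccc(OC)c3O)ccnc2c1` and compound 2 `COc1cccc(CNCCCNc2ccnc3cc(Cc4ccc(F)cc4)ccc23)c1O` share one core and were both run in an ADME assay for permeability, using PAMPA, with a stated time of 30 min, at pH 7.4; a lower number here means that the compound crosses the layer more slowly, a higher number that the compound crosses the layer faster. In this assay compound 1 gives 23 10^-6 cm/s. In the same assay compound 2 gives 23 10^-6 cm/s. Within the data shown here, the one step measured between them, no change at the digits printed from compound 1 to compound 2 (within the scatter), stayed within the scatter even though the exchange was sizeable, so compound 2 stands level with compound 1 on these numbers.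

Compound 3 `COc1cccc(CNCCCNc2ccnc3cc(Cc4ccc(C#N)cc4)ccc23)c1O` differs from compound 2 by cyano in place of fluoro on an aromatic carbon, the replacement sitting para to a large group. Among the measured compounds shown here, only the step from compound 1 to compound 2 bears on this case, and it showed no movement beyond the scatter. The step of a 1.2-fold lower number from compound 2 to compound 3 (0.06 log units; within the scatter) is therefore expected to stay inside the scatter, with no clear direction. Compound 3 is estimated at 20 10^-6 cm/s, within a range from 11 10^-6 cm/s to 34 10^-6 cm/s.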

Compound 3, apparent permeability: 23 10^-6 cm/s
Estimate against measurement, compound 3: 1.2-fold (0.06 log units) below; the measured number falls inside the stated range.
By their numbers in this assay, from the lowest: compounds 1, 2 and 3 (each within the scatter of the next).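

The result adds a second exchange at the same place on the shared core: in this assay, putting cyano, with its hydrogen-bond acceptor, where fluoro stood gives no change at the digits printed from compound 2 to compound 3 (within the scatter). Measured against the pentan-3-yl group, the 4-cyanobenzyl group likewise gives no change at the digits printed from compound 1 to compound 3 (within the scatter), so this assay does not separate these three groups at this place on the core. Nothing available accounts for this flat outcome.

As far as these compounds go, whether an amine or a carboxylic acid on the same aromatic carbon of the benzyl ring would move the number beyond the scatter remains open. From the compounds shown here alone, it is also open whether cyano in place of fluoro would behave the same way on a different core.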